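The source may hold more compounds than are shown below. What is called first, only, known or untested is meant among the compounds shown, and "the series" means these compounds.

Compound 1 `COc1ccc(Cl)cc1C(=O)NCC1CCN(S(=O)(=O)NC(=O)NC2CCCCC2)CC1` was examined in a functional assay on the whole organism (blood) with Rattus norvegicus as the target, with stated times of 24 h and 1 h, at a dose of 5 mg/kg by the intraperitoneal route (a lower number here means a weaker effect, a higher number a stronger effect of the compound at the dose given), and in this assay compound 1 gives 20%. Compound 2 `COc1ccc(Cl)cc1C(=O)NCC1CCN(S(=O)(=O)NC(=O)NC[C@@H]2C[C@@H]3C=C[C@@H]2C3)CC1` differs from compound 1 only by a group of 8 heavy atoms (8 carbon; 2 five-membered non-aromatic rings of carbon only) in place of a group of 6 heavy atoms (6 carbon; one six-membered non-aromatic ring of carbon only), on an amide-type nitrogen; in this assay compound 2 gives 15%. The step between the two is a number 5 percentage points lower from compound 1 to compound 2 (within the scatter). Compound 3 `COc1ccc2nccc(C(=O)NCCC3CCN(S(=O)(=O)NC(=O)NC4CCCCC4)CC3)c2c1` is built on a different core, and the difference between the cores of compound 1 and compound 3 is not broken down here. In this assay compound 3 gives 15%, level with compound 2 at the digits shown and within the scatter of compound 1. Compound 4 `COc1ccc2nccc(C(=O)NCCC3CCN(S(=O)(=O)NC(=O)NC[C@@H]4C[C@@H]5C=C[C@@H]4C5)CC3)c2c1` stands to compound 3 as compound 2 stands to compound 1: it carries a group of 8 heavy atoms (8 carbon; 2 five-membered non-aromatic rings of carbon only) in place of a group of 6 heavy atoms (6 carbon; one six-membered non-aromatic ring of carbon only), on an amide-type nitrogen, the same change at the same place. A small step is expected from compound 3 to compound 4, namely a number 3 percentage points lower from compound 3 to compound 4 (within the scatter), because a number 5 percentage points lower from compound 1 to compound 2 (within the scatter) lay within the scatter when the same change was made on the first core. On that basis compound 4 is estimated to give 12% in this assay, expected to fall between 0% and 28%.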

Compound 4, a percentage reported as activity, at one dose (the size of the read-out at that dose, not a potency): 10%
Compound 4: the middle estimate sits 2 percentage points above what was measured; measured number inside the range.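

In this assay, exchanging the cyclohexyl for the group with two five-membered carbon rings, on the amide-type nitrogen, gives a number 5 percentage points lower from compound 3 to compound 4 (within the scatter). Set beside the earlier step, the change reads the same on the two cores: the same change on two cores in this assay, a number 5 percentage points lower (within the scatter) from compound 1 to compound 2 and a number 5 percentage points lower (within the scatter) from compound 3 to compound 4, 0 percentage points apart, within the scatter of two such steps. Going by these compounds alone, this agreement shows only that neither core gives a step that stands out from the scatter; it does not show that the change truly lowers the read-out on either core, and two steps of this kind do not establish a rule for other cores.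

The compounds shown leave open how a phenyl ring, a longer open chain or a chain ending in an amine would read on that amide-type nitrogen in this assay. They also leave open whether the step would stay the same on a third core, and whether the compounds would separate at another dose.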